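Phenylethynyl Replacing Azidomethyl on a Deoxyuridine Core

A few compounds are considered here, and "the series" means these few. Any claim that something is new, unique, unknown or untested is made for them only; others in the source may bear on it.

The three measured compounds were tested in an ADME assay on L1210/0 cells (Mus musculus) for cytotoxicity, with a stated time of 48 h; a higher number here means a weaker inhibitor, a lower number a stronger inhibitor. Compound 1 `C#Cc1cn([C@@H]2O[C@H](CO)[C@@H](O)[C@@H]2O)c(=O)[nH]c1=O` gives 168000 nM. Compound 2 `[N-]=[N+]=NCc1cn([C@H]2C[C@H](O)[C@@H](CO)O2)c(=O)[nH]c1=O` gives 124000 nM; this number and that of compound 1 lie within the usual scatter of each other, so neither can be called the stronger of the two. Compound 3 `Nc1ncnc2c1ncn2C[C@@H]1C[C@H](CO)c2ccccc21` is recorded only as a limit of this assay, namely > 200000 nM, and not as a number. No two of these compounds differ in a single place, so no measured step is available.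

Compound 4 `O=c1[nH]c(=O)n([C@H]2C[C@H](O)[C@@H](CO)O2)cc1C#Cc1ccccc1` has not yet been tested. It shares its core with compound 2 and differs from it in one place: 2-phenylethynyl in place of azidomethyl on an aromatic carbon. The measured compounds contain no comparable exchange, so the size of the step from compound 2 to compound 4 cannot be read from them. The account nonetheless expects a move toward a lower number, of a size beyond the scatter, expressed as a 4.1-fold lower number from compound 2 to compound 4 (0.62 log units; beyond the scatter). On that basis compound 4 is estimated to give 30000 nM in this assay, with a range from 5000 nM to 180000 nM.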

Compound 4, half-maximal inhibitory concentration: > 200000 nM
Compound 4: no number, only a limit; the forecaster's own chance of this, stated with the estimate: 10%; at least 6.6-fold (0.82 log units) between middle value and limit.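

Among the compounds shown here, at the aromatic carbon of the shared core, the exchange of azidomethyl for 2-phenylethynyl now has a measured step, which the earlier compounds could not supply: an at least 1.6-fold higher number from compound 2 to compound 4 (0.20 log units; that floor lies within the scatter) in this assay. This step is a floor rather than a size, and it shows that the larger group, with its six-membered aromatic ring and triple bond, gives no lower number at this position. Compound 4 is recorded only as a limit of this assay, > 200000 nM, and this bounds what can be read from the step: the limit of > 200000 nM in this assay, at which 2 of the 4 values shown sit.

The compounds shown leave open how far compound 4 really lies from compound 2, and so whether the true step goes beyond the scatter or not. They also leave open how an aminomethyl group, a carboxylic acid or a plain phenyl group at this aromatic carbon of the shared core would read in this assay, and so whether the triple bond or the aromatic ring of 2-phenylethynyl goes with the reading of compound 4.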